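This account rests on a few compounds, and the source may have more. Where it says the series, first, only, none or still open, it means among the compounds named here.

All three measured compounds were tested in a functional assay (aorta) with Rattus norvegicus as the target; a higher number here means that more compound is needed for the effect, a lower number that less compound is needed:

Compound 1 `COc1ccc(-c2nc(CN(C)C)sc2-c2ccc(OC)cc2)cc1` gives 8.4 uM.
Compound 2 `COc1ccc(-c2nc(CNC(=O)CSC)sc2-c2ccc(OC)cc2)cc1` gives 6 uM.
Compound 3 `COc1ccc(-c2nc(CNC(=O)C3=NNC(=O)CC3)sc2-c2ccc(OC)cc2)cc1` gives 7.3 uM.

Compound 2 sits in the same band as its two neighbours: a 1.4-fold lower number from compound 1 to compound 2 (0.15 log units; within the scatter) and a 1.2-fold higher number from compound 2 to compound 3 (0.09 log units; within the scatter), and the third step, a 1.2-fold lower number from compound 1 to compound 3 (0.06 log units; within the scatter), is likewise within the scatter. All three measured compounds share the same core and differ only in the group on a saturated chain carbon bound to an aromatic carbon, and none of those changes moved the number beyond the scatter.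

Compound 4 `CCOC(=O)/C(C#N)=C/c1nc(-c2ccc(OC)cc2)c(-c2ccc(OC)cc2)s1` departs from compound 2 in a different way: 2-cyano-2-(ethoxycarbonyl)ethenyl in place of ((((methylsulfanyl)methyl)carbonyl)amino)methyl on an aromatic carbon. The three measured steps bear on it only loosely, since each of them kept that saturated chain carbon and changed what hangs from it, while here the whole chain is replaced. Still, they show that this position has so far accepted groups of quite different size and make-up with no step beyond the scatter. Among the measured compounds shown here, with no closer precedent, the expectation for compound 4 is a step of a 1.2-fold higher number from compound 2 to compound 4 (0.07 log units; within the scatter), that is, no change beyond the scatter. Compound 4 is therefore estimated at 7 uM, with a range from 3 uM to 20 uM.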

Compound 4, concentration for half-maximal effect: > 100 uM
Compound 4 ended at the assay's limit (the forecaster's own chance of this, stated with the estimate: 10%); middle value at least 14-fold (1.15 log units) away from the limit.
By their numbers in this assay, from the lowest: compounds 2, 3 and 1 (each within the scatter of the next). At a limit, above all of these: compound 4.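

The reading for compound 4 in this assay is a limit of the assay and not a number: the limit of > 100 uM in this assay, at which 1 of the 4 values shown sits.

Even with that limit, both steps are large and beyond the scatter: an at least 16-fold higher number from compound 2 to compound 4 (1.22 log units; beyond the scatter), and an at least 11-fold higher number from compound 1 to compound 4 (1.07 log units; beyond the scatter). The earlier compounds shown here, which all kept the saturated chain carbon and changed only what hangs from it, stayed within one band and gave the impression of a tolerant position, whereas this change shows that the position on the aromatic carbon, next to the ring nitrogen and next to the ring sulfur, does not accept every group.

The change swaps several things at once: the saturated chain carbon and the amide hydrogen leave, while a carbon-carbon double bond, a nitrile and an ethyl ester enter, and the compounds shown cannot say which of these matters. A plain ethenyl group without the nitrile and ester, or a carboxylic acid or an ethyl ester held on a saturated chain carbon, would help separate these parts and show whether keeping that chain carbon is what counts.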